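A few compounds are considered here, and "the series" means these few. Any claim that something is new, unique, unknown or untested is made for them only; others in the source may bear on it.

Compound 1 `CC(C)=Cc1nc(Nc2ccccc2)c2cc([N+](=O)[O-])ccc2n1`: > 125000 nM
Compound 2 `CC(C)=Cc1nc(Nc2cccc(C(F)(F)F)c2)c2cc([N+](=O)[O-])ccc2n1`: > 125000 nM

In a functional assay on K562 cells (Homo sapiens) for cytotoxicity, read by flow cytometry, with a stated time of 72 h (on this read-out lower numbers stand for stronger inhibition and higher numbers for weaker inhibition), compound 1 gives > 125000 nM, which is a limit and not a number. Compound 2 gives > 125000 nM, which is also a limit. All that has been measured so far is therefore (the limit of > 125000 nM in this assay, at which 2 of the 2 values shown sit).

Compound 3 `CC(C)=Cc1nc(Nc2ccc(F)cc2)c2cc([N+](=O)[O-])ccc2n1` differs from compound 1 in one place: fluoro in place of hydrogen on an aromatic carbon. This single change turns phenyl into 4-fluorophenyl.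

Within the data shown here, the one measured step that bears on this change is a step that the two limits leave unreadable from compound 1 to compound 2. It has no readable size, so it offers no basis for expecting a change in either direction, and no step beyond the scatter is expected in this assay. The expected change is a step that the limit leaves unreadable from compound 1 to compound 3. For compound 3 the estimated value is 140000 nM, with an expected range from 60000 nM to 300000 nM, and the assay may well report only a limit again.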

Compound 3, half-maximal inhibitory concentration: > 62000 nM
Compound 3: no number, only a limit; the forecaster's own chance of this, stated with the estimate: 85%; the middle value lies beyond the limit too.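

Compound 1 and compound 3 each give only a limit and not a number, so the step between them cannot be read. The compounds shown leave open whether any of them has a measurable value in this assay, and whether fluoro changes that value at all.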